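Swapping amino for methyl on the shared core

The source may hold more compounds than are shown below. What is called first, only, known or untested is meant among the compounds shown, and "the series" means these compounds.

Compound 1 `Cc1ccc(N(C)c2nc(C)nc3c2CCC3)cc1`: 360 nM
Compound 2 `CCOc1ccc(N(C)c2nc(N)nc3c2CCC3)cc1`: 20.3 nM

Both values come from a functional assay on MDA-MB-435 cells (Homo sapiens) for inhibition, read by sulforhodamine B assay, with a stated time of 48 h; on this read-out higher numbers stand for weaker inhibition and lower numbers for stronger inhibition. Compound 2 has the lower of the two numbers, and the gap up to compound 1 lies beyond the scatter. These two compounds differ in more than one place, so their gap cannot be assigned to any single group.

Compound 3 `CCOc1ccc(N(C)c2nc(C)nc3c2CCC3)cc1` keeps everything in compound 2 except one group: methyl in place of amino on an aromatic carbon, between two ring nitrogen atoms (methyl in place of amino on an aromatic carbon). Going by the values given here, no measured pair isolates this change. Compound 1 carries methyl at the same place and gives 360 nM, but it differs from compound 3 elsewhere. A modest weakening, only just beyond the scatter, is expected, and the estimated step is a 2.5-fold higher number from compound 2 to compound 3 (0.39 log units; beyond the scatter). For compound 3 the estimated value is 50 nM, with an expected range of 12 nM to 220 nM.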

Compound 3, half-maximal inhibitory concentration: 15.1 nM
Beside the measured number, compound 3's estimate is 3.3-fold (0.52 log units) above it; low and high end bracket the measured number.
By their numbers in this assay, from the lowest: compounds 3 and 2 (each within the scatter of the next); then compound 1.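

With methyl in place of amino on the aromatic carbon between two ring nitrogen atoms, this assay shows a 1.3-fold lower number from compound 2 to compound 3 (0.13 log units; within the scatter), so this pair gives no sign that amino is needed at this position when ethoxy is present. The large change lies at the other site: ethoxy in place of methyl on an aromatic carbon gives a 24-fold lower number from compound 1 to compound 3 (1.38 log units; beyond the scatter), a single-place comparison that compound 1 and compound 2 could not provide. No available data bear on what lies behind either step.

Still open, from the compounds shown here alone, is whether larger or differently built groups at the position between two ring nitrogen atoms, such as a dimethylamino group or a longer chain, would keep this level. Also open, going by these compounds, is whether methoxy or propoxy would serve in place of ethoxy.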